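The compounds below may be only part of what the source reports. "The series", "measured", "known", "first", "only" and "open" are said of these compounds alone.

Compounds measured so far:
compound 1, `CN1CCN(CCCCCn2c3c(c4ccccc42)C(=O)c2c[n+]([O-])c4ccccc4c2C3=O)CC1` — 870 nM
compound 2, `O=C1c2c[n+]([O-])c3ccccc3c2C(=O)c2c1c1ccccc1n2Cc1cn(C[C@@H](O)CO)nn1` — 390 nM
compound 3, `O=C1c2c[n+]([O-])c3ccccc3c2C(=O)c2[nH]c3ccccc3c21` — 320 nM

All three were tested in a functional assay on A549 cells (Homo sapiens) for cytotoxicity, read by MTT assay, with a stated time of 72 h; a lower number here means a stronger inhibitor, a higher number a weaker inhibitor. Compound 2 stands second highest of the three numbers; its nearest neighbour is compound 3, with a 1.2-fold lower number from compound 2 to compound 3 (0.09 log units; within the scatter), and its furthest is compound 1, with a 2.2-fold lower number from compound 1 to compound 2 (0.35 log units; beyond the scatter).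

The new compound, compound 4 `CC1(C)OCC(Cn2cc(Cn3c4c(c5ccccc53)C(=O)c3c[n+]([O-])c5ccccc5c3C4=O)nn2)O1`, differs from compound 2 in one place: 2,2-dimethyl-1,3-dioxolan-4-yl in place of 1,2-dihydroxyethyl on a saturated chain carbon bound to an aromatic nitrogen. Cut one bond further out, the 2,3-dihydroxypropyl of compound 2 becomes (2,2-dimethyl-1,3-dioxolan-4-yl)methyl. Within the data shown here, no measured pair shows this exact exchange, so the comparison rests on how much the group on the aromatic nitrogen has mattered at all. Between compound 1 and compound 2 the whole side chain was swapped for a different one, and between compound 2 and compound 3 it was removed entirely, giving a 2.2-fold lower number from compound 1 to compound 2 (0.35 log units; beyond the scatter) and a 1.2-fold lower number from compound 2 to compound 3 (0.09 log units; within the scatter). Both steps are small; the second sits within the scatter. A change at the outer end of the chain in compound 4 is therefore expected to move the number little, if at all, and the estimated step is a 1.1-fold higher number from compound 2 to compound 4 (0.03 log units; within the scatter). Compound 4 is thus expected to give 420 nM in this assay, with a range from 200 nM to 900 nM.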

Compound 4, half-maximal inhibitory concentration: 80 nM
Compound 4: middle estimate off by 5.3-fold (0.72 log units), on the high side; measured number outside the range, below it.
By their numbers in this assay, from the lowest: compound 4; then compounds 3 and 2 (each within the scatter of the next); then compound 1.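

Among these compounds, until this result, the group on the aromatic nitrogen had looked close to silent in this assay: removing the whole side chain gave a 1.2-fold lower number from compound 2 to compound 3 (0.09 log units; within the scatter) and exchanging it for a different chain gave only a 2.2-fold lower number from compound 1 to compound 2 (0.35 log units; beyond the scatter) as the step. The change at the saturated chain carbon bound to an aromatic nitrogen, where 2,2-dimethyl-1,3-dioxolan-4-yl replaces 1,2-dihydroxyethyl, gives a 4.9-fold lower number from compound 2 to compound 4 (0.69 log units; beyond the scatter) as the step, so this part of the side chain can matter even though removing the chain altogether left the number within the scatter. The exchange removes the 2 hydrogen-bond donors, adds a five-membered non-aromatic ring, and raises the group from 4 to 7 heavy atoms, but nothing available here accounts for the step.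

These compounds leave open whether the step follows from capping the two hydroxyl groups or from the ring with its two methyl groups, since both change together in compound 4. An open-chain dimethyl ether or a single methyl ether at the same place would begin to separate these two changes, and a spiro-cyclohexane ketal would show whether the two methyl groups can be replaced.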